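From Piperidin-1-yl to Acetamido on a Shared Core

This account rests on a few compounds, and the source may have more. Where it says the series, first, only, none or still open, it means among the compounds named here.

In an ADME assay on GM00637 cells (Homo sapiens) for cytotoxicity, read by MTT assay, with a stated time of 72 h (on this read-out higher numbers stand for weaker inhibition and lower numbers for stronger inhibition), compound 1 `Nc1cc2nc(-c3ccccc3)nn(-c3ccccc3)c-2cc1=O` gives 2040 nM, compound 2 `CCNc1cc2nc(-c3ccccc3)nn(-c3ccccc3)c-2cc1=O` gives 240 nM, and compound 3 `O=c1cc2n(-c3ccccc3)nc(-c3ccccc3)nc-2cc1N1CCCCC1` gives 1190 nM. Compound 3 therefore stands within the scatter of compound 1, as a 1.7-fold lower number from compound 1 to compound 3 (0.23 log units; within the scatter) shows, while a 5.0-fold higher number from compound 2 to compound 3 (0.70 log units; beyond the scatter) places its number clearly above that of compound 2. The next structure is compound 4 `CC(=O)Nc1cc2nc(-c3ccccc3)nn(-c3ccccc3)c-2cc1=O`, described by acetamido in place of piperidin-1-yl on an aromatic carbon, with acetamido in place of piperidin-1-yl on an aromatic carbon. Within the data shown here, no measured compound carries acetamido, so the evidence is indirect. Ethyl in place of hydrogen on the nitrogen produced an 8.5-fold lower number from compound 1 to compound 2 (0.93 log units; beyond the scatter), the largest measured step, yet piperidin-1-yl in place of amino produced only a 1.7-fold lower number from compound 1 to compound 3 (0.23 log units; within the scatter). With compound 2 at 240 nM and compound 1 at 2040 nM marking the measured span, a position inside that span is expected. The expected change is a 1.5-fold lower number from compound 3 to compound 4 (0.17 log units; within the scatter), so no step beyond the scatter is anticipated in this assay. For compound 4 the estimated value is 800 nM, with an expected range from 250 nM to 2500 nM.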

Compound 4, half-maximal inhibitory concentration: > 5000 nM
Compound 4: only a limit was reported; the forecaster's own chance of this, stated with the estimate: 5%; middle value at least 6.2-fold (0.79 log units) away from the limit.
By their numbers in this assay, from the lowest: compound 2; then compounds 3 and 1 (each within the scatter of the next). At a limit, above all of these: compound 4.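

In this assay compound 4 is recorded only as a limit: the limit of > 5000 nM in this assay, at which 1 of the 4 values shown sits. On this aromatic carbon, acetamido departs from all three earlier groups, with an at least 4.2-fold higher number from compound 3 to compound 4 (0.62 log units; beyond the scatter), an at least 2.4-fold higher number from compound 1 to compound 4 (0.38 log units; beyond the scatter) and an at least 20-fold higher number from compound 2 to compound 4 (1.31 log units; beyond the scatter), the last being the largest step seen at this position. The nitrogen now gives opposite directions: acetyl in place of hydrogen raises the number, whereas ethyl in place of hydrogen gives an 8.5-fold lower number from compound 1 to compound 2 (0.93 log units; beyond the scatter), so substitution on that nitrogen does not by itself set the direction.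

The compounds shown leave open whether a propionyl or benzoyl group on that nitrogen would follow acetyl, and whether a propyl chain would follow ethyl. The limit also leaves open how far the true number of compound 4 lies from the other three.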